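This account rests on a few compounds, and the source may have more. Where it says the series, first, only, none or still open, it means among the compounds named here.

Working notes on the series in a functional assay on MCF7 cells (Homo sapiens) for cytotoxicity, read by MTT assay, with a stated time of 24 h; a lower number here means a stronger inhibitor, a higher number a weaker inhibitor. Compound 1 `C/C(=N\NC(=O)/C(C#N)=C/c1ccccc1)c1c(O)c2ccc(O)cc2oc1=O` gives 19200 nM, compound 2 `COc1ccc(/C=C(\C#N)C(=O)N/N=C(\C)c2c(O)c3ccc(O)cc3oc2=O)cc1OC` gives 14400 nM, and compound 3 `COc1ccc(/C=C(\C#N)C(=O)N/N=C(\C)c2c(O)c3ccc(O)cc3oc2=O)cc1` gives 8940 nM. The only separation among these three is a 2.1-fold lower number from compound 1 to compound 3 (0.33 log units; beyond the scatter), and it is modest. The other two comparisons give a 1.3-fold lower number from compound 1 to compound 2 (0.12 log units; within the scatter) and a 1.6-fold lower number from compound 2 to compound 3 (0.21 log units; within the scatter). Compound 3 can therefore be told apart from compound 1, but not from compound 2.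

Compound 4 `C/C(=N\NC(=O)/C(C#N)=C/c1ccc(Br)cc1)c1c(O)c2ccc(O)cc2oc1=O` is the next analogue to consider. Relative to compound 3 the change is bromo in place of methoxy on an aromatic carbon, para to a large group, which reads as 4-methoxyphenyl to 4-bromophenyl. Within the data shown here, no bromo compound has been measured, so the evidence is indirect. All three measured steps change only the substituents on this same aromatic ring, and none is large. The biggest is the modest step from the unsubstituted phenyl, a 2.1-fold lower number from compound 1 to compound 3 (0.33 log units; beyond the scatter).

A small move towards a higher number is expected, with no step beyond the scatter in this assay, and the estimated change is a 1.3-fold higher number from compound 3 to compound 4 (0.13 log units; within the scatter). For compound 4 the expected value is 12000 nM, with an estimated range of 6000 nM to 24000 nM.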

Compound 4, half-maximal inhibitory concentration: 9850 nM
Compound 4: the middle estimate sits 1.2-fold (0.09 log units) above what was measured; the measured number falls inside the stated range.
By their numbers in this assay, from the lowest: compounds 3, 4, 2 and 1 (each within the scatter of the next, the first and the last beyond it).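

At this position, para to a large group, the single bromo atom takes the place of the two-atom methoxy without a readable shift in this assay (a 1.1-fold higher number from compound 3 to compound 4 (0.04 log units; within the scatter)), so the hydrogen-bond acceptor counted on methoxy is not needed to reach this range of values. Bromo in place of hydrogen gives a step that stays within the scatter (a 1.9-fold lower number from compound 1 to compound 4 (0.29 log units; within the scatter)), and the comparison with the 3,4-dimethoxyphenyl analogue does the same (a 1.5-fold lower number from compound 2 to compound 4 (0.16 log units; within the scatter)), so compound 4 cannot be told apart from any of the three earlier compounds, whereas compound 3 can be told apart from compound 1. No measurement at hand bears on why these steps are as small as they are.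

The compounds shown carry only hydrogen, methoxy and bromo on this ring, so it remains open whether an amine or a carboxylic acid at the same position would move the number beyond the scatter. On these data alone, it also remains open whether chloro or fluoro would behave as bromo does here, and whether any change on this ring can take the series much below the values seen so far.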